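Benzyl to cyclohexylmethyl amide: expectation for compound 3

The source may hold more compounds than are shown below. What is called first, only, known or untested is meant among the compounds shown, and "the series" means these compounds.

Measured so far:
compound 1, `CCOC(=O)c1ccc(N2C(=O)N/C(=C\c3ccc(O)cc3)C2=O)cc1`, > 200000 nM in a functional assay on NCI-H292 cells (Homo sapiens) for antiproliferative activity; on this read-out higher numbers stand for weaker inhibition and lower numbers for stronger inhibition
compound 2, `O=C(NCc1ccccc1)c1ccc(N2C(=O)N/C(=C\c3ccc(O)cc3)C2=O)cc1`, > 200000 nM in this assay

Compound 1 reaches only the limit of this assay, > 200000 nM. Compound 2 likewise reaches only the limit, > 200000 nM. Hence the step that the two limits leave unreadable from compound 1 to compound 2 cannot be read; (the limit of > 200000 nM in this assay, at which 2 of the 2 values shown sit). Compound 3, `O=C(NCC1CCCCC1)c1ccc(N2C(=O)N/C(=C\c3ccc(O)cc3)C2=O)cc1`, differs from compound 2 by cyclohexyl in place of phenyl on a saturated chain carbon bound to an amide-type nitrogen. No measured step covers this change, and the one step shown is unreadable. Compound 3 is therefore expected to sit at or beyond the same limit, with a step that the limit leaves unreadable from compound 2 to compound 3 meaning no change that can be read. Compound 3 is estimated at 300000 nM, within 100000 nM to 1000000 nM.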

Compound 3, half-maximal inhibitory concentration: > 200000 nM
Compound 3 gave a limit, no number; the forecaster's own chance of this, stated with the estimate: 85%; the middle value lies beyond the limit too.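

No step among compound 1, compound 2 and compound 3 can be read in this assay: the limit of > 200000 nM in this assay, at which 3 of the 3 values shown sit.

The compounds shown leave open whether any change on the shared core gives a readable value, and how the ethoxy, benzylamino and (cyclohexylmethyl)amino groups truly compare.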